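The source may hold more compounds than are shown below. What is called first, only, known or untested is meant among the compounds shown, and "the series" means these compounds.

Measured compounds:
compound 1, `Cc1ccccc1/C(CCN1CCN(c2ccccn2)CC1)=N\O`, 72%
compound 2, `O/N=C(\CCN1CCN(c2ccccn2)CC1)c1cccc(F)c1`, 72%

In a functional assay on HEK293 cells with D(4) dopamine receptor (Homo sapiens) as the target, read by FLIPR (a lower number here means a smaller maximal response, a higher number a larger maximal response), compound 1 gives 72% and compound 2 gives 72%. Compound 2 thus stands level with compound 1 at the digits shown, the two values lying within the scatter of each other, so nothing can be said of an order between them. Compound 3, `O/N=C(\CCN1CCN(c2ccccn2)CC1)c1cc(F)cc(F)c1`, has not yet been measured. It differs from compound 2 in one place: fluoro in place of hydrogen on an aromatic carbon. Among the measured compounds shown here, no step between measured compounds is given, so the account rests on the two values alone. The expected step from compound 2 to compound 3, a number 2 percentage points lower from compound 2 to compound 3 (within the scatter), is none beyond the scatter. Compound 3 is therefore estimated to give 70%, with a range from 55% to 85%.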

Compound 3, largest response reached (reported as efficacy), in percent of the reference or control that the assay uses: 74%
The estimate for compound 3 lay 4 percentage points below the measured number; low and high end bracket the measured number.
By their numbers in this assay, from the lowest: compounds 1, 2 and 3 (each within the scatter of the next).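

Taking 3-fluorophenyl to 3,5-difluorophenyl, this assay shows a number 2 percentage points higher from compound 2 to compound 3 (within the scatter), so this aromatic carbon, meta to a fluoro group, carries a fluoro in place of hydrogen with the maximal response staying within the scatter. Nothing measured here gives a reason for this result.

The compounds shown leave open whether a larger group at this place, such as trifluoromethyl or methoxy, or an amine, would also leave the maximal response within the scatter. They also leave open whether the same holds with the oxime hydroxyl replaced by a methoxy group.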